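Series notes: amine substituent on the shared core

The source may hold more compounds than are shown below. What is called first, only, known or untested is meant among the compounds shown, and "the series" means these compounds.

Three compounds share a core carrying a nitrile and a trifluoromethyl-pyridinylmethylamino group, and differ in the substituent on the other nitrogen on the aromatic ring. Compound 1 `N#Cc1cnc(NCc2cnccc2C(F)(F)F)cc1NC[C@H]1C[C@@H](O)C1` gives 4200 nM in an assay on isolated protein for inhibition of protein kinase C delta type (Homo sapiens), read by TR-FRET, with a stated time of 2 h; a higher number here means a weaker inhibitor, a lower number a stronger inhibitor. Compound 2 `N#Cc1cnc(NCc2cnccc2C(F)(F)F)cc1NC[C@H]1C[C@H](O)C1` reaches only the limit of this assay, > 10000 nM. Compound 3 `CO[C@H]1CC[C@H](Nc2cc(NCc3cnccc3C(F)(F)F)ncc2C#N)CC1` likewise sits at the limit of this assay, > 10000 nM, so it stands among the weakest values shown, with no number of its own. The step of an at least 2.3-fold higher number from compound 1 to compound 3 (0.37 log units; beyond the scatter) is at least modest and points towards weaker inhibition; the step that the two limits leave unreadable from compound 2 to compound 3 cannot be read, and both of these rest on (the limit of > 10000 nM in this assay, at which 2 of the 3 values shown sit). The mirror-image step an at least 2.3-fold higher number from compound 1 to compound 2 (0.37 log units; beyond the scatter) is also beyond the scatter, which rests on (the fact that compounds 1 and 2 differ only in the configuration as drawn).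

Compound 4 `N#Cc1cnc(NCc2cnccc2C(F)(F)F)cc1NCCC1CCOCC1` differs from compound 3 by 2-(oxan-4-yl)ethyl in place of 4-methoxycyclohexyl on a nitrogen on an aromatic ring. Within the data shown here, the only readable step that bears on a change at this nitrogen is an at least 2.3-fold higher number from compound 1 to compound 3 (0.37 log units; beyond the scatter), which weakened inhibition. Compound 4 is therefore expected to stay weak, with an estimated step of an at least 1.2-fold lower number from compound 3 to compound 4 (0.09 log units; that floor lies within the scatter) that the limit of compound 3 leaves unreadable. The estimate for compound 4 in this assay is 8000 nM, within the range 2500 nM to 25000 nM, with a real chance that only a limit is reported.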

Compound 4, half-maximal inhibitory concentration: > 10000 nM
Compound 4 was reported as a limit; the forecaster's own chance of this, stated with the estimate: 45%; middle value at least 1.2-fold (0.09 log units) away from the limit.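

In this assay compound 4 is reported only as a limit, > 10000 nM. With (oxan-4-yl)methyl in place of 3-hydroxycyclobutyl on a saturated chain carbon bound to a nitrogen on an aromatic ring, the result is an at least 2.3-fold higher number from compound 1 to compound 4 (0.37 log units; beyond the scatter), so a second group, now with a chain and a ring holding a hetero atom, also falls short of the group in compound 1, though the true size of the loss stays hidden behind the limit. The steps to compound 4 from compound 2 and from compound 3 cannot be read, and no order among these three compounds can be given: the limit of > 10000 nM in this assay, at which 3 of the 4 values shown sit.

Among these compounds, compound 1 remains the only compound in this set with a number of its own, and how far compounds 2, 3 and 4 lie from it, or from one another, stays open. Also open, going by these compounds, is whether an amine or a carboxylic acid in place of the hydroxyl on the cyclobutyl group, or a longer chain on this nitrogen, would bring a measured value back within the range of this assay.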